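Exposure notes: from compound 1 to compound 3

The source may hold more compounds than are shown below. What is called first, only, known or untested is meant among the compounds shown, and "the series" means these compounds.

Measured in an ADME assay on the whole organism (plasma, strain CD-1) for pharmacokinetics, with Mus musculus as the target, at a dose of 30 mg/kg by the oral route; on this read-out higher numbers stand for higher exposure at the dose given and lower numbers for lower exposure:
- compound 1 `O=C(CCSc1nc2ccccc2c(=O)[nH]1)N[C@H]1CC[C@H](c2nnc(-c3ccccc3)o2)CC1`: 23500 ng.h/mL
- compound 2 `O=C(CCSc1nc2c(c(=O)[nH]1)CCCC2)N[C@H]1CC[C@H](c2nnc(-c3ccccc3)o2)CC1`: 2540 ng.h/mL

Compound 1 holds the higher of the two numbers in this assay. Compound 3 `N#Cc1ccc(O[C@H]2CC[C@H](NC(=O)CCSc3nc4ccccc4c(=O)[nH]3)CC2)cc1Cl` has not yet been measured. Its change is 3-chloro-4-cyanophenoxy in place of 5-phenyl-1,3,4-oxadiazol-2-yl on a saturated ring carbon. Within the data shown here, the only measured step, a 9.3-fold lower number from compound 1 to compound 2 (0.97 log units; beyond the scatter), is a modest one beyond the scatter. It concerns a group on a sulfur, so it says nothing direct about this change and serves only as a guide to step size. Among the measured compounds shown here, no measured step shows the direction for this replacement. A lower number is tentatively expected, since compound 1 already gives 23500 ng.h/mL. The estimated change is a 2.9-fold lower number from compound 1 to compound 3 (0.47 log units; beyond the scatter), similar in scale to the measured step or smaller. For compound 3 the estimate is 8000 ng.h/mL, with an expected range of 1500 ng.h/mL to 40000 ng.h/mL.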

Compound 3, area under the concentration-time curve: 48300 ng.h/mL
Compound 3: middle estimate off by 6.0-fold (0.78 log units), on the low side; measured number above the stated range.
By their numbers in this assay, from the lowest: compound 2; then compound 1; then compound 3.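

On the saturated ring carbon, 3-chloro-4-cyanophenoxy in place of 5-phenyl-1,3,4-oxadiazol-2-yl raises the number in this assay (a 2.1-fold higher number from compound 1 to compound 3 (0.31 log units; beyond the scatter)). Among these compounds, the earlier step concerned only the group on a sulfur, so this is the first reading at this ring carbon. On this single pair, 5-phenyl-1,3,4-oxadiazol-2-yl is not needed to reach the exposure of compound 1. No measured data explain the rise.

Open, from the compounds shown here alone, is how the chlorine, the nitrile and the ether oxygen each contribute, and how a plain phenoxy or an amine at the same ring carbon would compare. Also open, going by these compounds, is whether the lower number of compound 2 would carry over to a compound with its group on the sulfur and 3-chloro-4-cyanophenoxy on the ring carbon.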